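The source may report more compounds than this note shows. Statements on the series, on what has been measured and on what is new or still open speak of the compounds shown alone.

Measured compounds:
- compound 1, `CC(C)CC1n2cncc2CN(Cc2ccc(OC(F)(F)F)cc2)S1(=O)=O`, which in an assay on isolated protein for inhibition of Aromatase (Homo sapiens), tested at 1 uM (on this read-out higher numbers stand for more inhibition at the one concentration tested (going by the name of the read-out) and lower numbers for less inhibition), gives 13%
- compound 2, `CC(C)CC1n2cncc2CN(C2CC2)S1(=O)=O`, which in this assay gives 9%
- compound 3, `COC(C)(C)CC1n2cncc2CN([C@@H](C)c2ccc(Cl)cc2)S1(=O)=O`, which in this assay gives 17%

Compound 3 carries the largest of the three numbers, but the gap to compound 1, the nearest of the other two, and the gap to compound 2, the furthest, both lie within the usual scatter of this kind of measurement, so the three compounds cannot be ranked against each other; all sit at a low level of inhibition.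

Compound 4, `C[C@@H](c1ccc(Cl)cc1)N1Cc2cncn2C(C[C@H](O)c2ccccc2)S1(=O)=O`, has not yet been measured. It differs from compound 3 in a single place: hydroxy(phenyl)methyl in place of 1-methoxy-1-methylethyl on a saturated chain carbon bound to a saturated ring carbon. Among the measured compounds shown here, no pair of measured compounds that differ in one place is available, so no measured step can guide this change. With every measured number low and close together, the step of a number 3 percentage points higher from compound 3 to compound 4 (within the scatter) is expected to be small, not beyond the scatter, with at most a slight lean upward. Compound 4 is therefore estimated at 20%, with a range from 5% to 40%.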

Compound 4, a percentage reported as inhibition, at one concentration (the size of the read-out at that concentration, not a potency): 6%
Estimate against measurement, compound 4: 14 percentage points above; the measured number falls inside the stated range.
By their numbers in this assay, from the lowest: compounds 4, 2, 1 and 3 (each within the scatter of the next, the first and the last beyond it).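

In this assay, hydroxy(phenyl)methyl in place of 1-methoxy-1-methylethyl on a saturated chain carbon bound to a saturated ring carbon gives a number 11 percentage points lower from compound 3 to compound 4 (beyond the scatter) and provides the first change in a single place among these compounds. It shows that this position can move the number beyond the usual scatter, and that bringing in a six-membered aromatic ring and a hydrogen-bond donor here lowers inhibition rather than raising it. No measurement shown explains the drop, and this one step cannot separate the contribution of the ring from that of the hydroxy group.

From the compounds shown here alone, it remains open whether a plain 2-phenylethyl chain or a 2-hydroxypropyl chain would give a similar number. Going by these compounds, the effect of an amine at this position and of the opposite configuration at the hydroxy-bearing carbon also remains unknown.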